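This account rests on a few compounds, and the source may have more. Where it says the series, first, only, none or still open, it means among the compounds named here.

Compound 1 `O=C(O)/C(S)=C/c1c[nH]c2cc(Cl)ccc12` carries a chloro group on its fused aromatic core, and compound 2 `O=C(O)/C(S)=C/c1c[nH]c2cc(F)ccc12` carries a fluoro group in the same position. In an assay on isolated protein for inhibition of Calpain-1 catalytic subunit (Sus scrofa), read by FRET (a lower number here means a stronger inhibitor, a higher number a weaker inhibitor), compound 1 gives 210 nM, while compound 2 gives 10 nM, which is a 21-fold lower number from compound 1 to compound 2 (1.32 log units; beyond the scatter). The change between them is fluoro in place of chloro on an aromatic carbon. Compound 3 `O=C(O)/C(S)=C/c1ccc(Cl)cc1` is built on a different core; the difference between the core of compound 1 and the core of compound 3 is not broken down here. In this assay compound 3 gives 2600 nM. Compound 4 `O=C(O)/C(S)=C/c1ccc(F)cc1` differs from compound 3 by fluoro in place of chloro on an aromatic carbon, the same kind of change as from compound 1 to compound 2, though here the place is para to a group of 6 heavy atoms on a ring that is not part of a fused system, rather than meta and para to a fused ring. Because the measured change was a 21-fold lower number from compound 1 to compound 2 (1.32 log units; beyond the scatter), the expected step is a 5.2-fold lower number from compound 3 to compound 4 (0.72 log units; beyond the scatter), smaller since a single example on another core is a thin basis. Compound 4 is therefore estimated at 500 nM, expected to fall between 150 nM and 1500 nM.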

Compound 4, half-maximal inhibitory concentration: 6900 nM
Compound 4: the middle estimate sits 14-fold (1.14 log units) below what was measured, outside the stated range (above it).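

Fluoro in place of chloro gives a 2.7-fold higher number from compound 3 to compound 4 (0.42 log units; beyond the scatter) in this assay, which runs in the opposite direction to the earlier step on the core of compound 1. Set side by side, the two steps clearly differ: the same change on two cores in this assay, a 21-fold lower number (1.32 log units; beyond the scatter) from compound 1 to compound 2 and a 2.7-fold higher number (0.42 log units; beyond the scatter) from compound 3 to compound 4, 56-fold (1.75 log units) apart, beyond the scatter of two such steps. The gain seen on the core of compound 1 therefore does not carry over to the core of compound 3, although two pairs cannot show why the steps differ or predict the change on a further core.

The compounds shown leave open how other groups in the same place, such as bromo, methoxy or a nitrile, would compare with fluoro and chloro on either core.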